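The source may report more compounds than this note shows. Statements on the series, on what has been measured and on what is new or still open speak of the compounds shown alone.

Measured in an assay on isolated protein for inhibition of Rho-associated protein kinase 2 (Homo sapiens), read by scintillation counting, radiometric assay and 33P incorporation, with a stated time of 40 min, in the presence of a further agent that is not named here; a higher number here means a weaker inhibitor, a lower number a stronger inhibitor:
compound 1 `COc1ccc(OCC(=O)Nc2cccc(NC(=O)c3ccc(N(C)C)cc3)c2)cc1OC` gives > 10000 nM; compound 2 `CN(C)c1ccc(C(=O)Nc2cccc(NC(=O)COc3ccc4c(c3)OCCC4=O)c2)cc1` gives 85 nM; compound 3 `Cc1ccc(C(=O)Nc2cccc(NC(=O)COc3ccc4c(=O)ccoc4c3)c2)cc1` gives 22 nM.

The value of compound 1 is a limit of this assay, not a number (the limit of > 10000 nM in this assay, at which 1 of the 3 values shown sits). Of the two numbers, compound 3 stands at the lower, compound 2 at the higher. For the measured compounds named here, the one step measured in one place, an at least 110-fold lower number from compound 1 to compound 2 (2.07 log units; beyond the scatter), concerns the ether side of the shared core and is large.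

Compound 4 `Cc1cc(C(=O)Nc2cccc(NC(=O)COc3ccc4c(=O)ccoc4c3)c2)ccc1C(F)(F)F` differs from compound 3 on the other side: a group of 11 heavy atoms (8 carbon, 3 fluorine; one six-membered aromatic ring of carbon only) in place of a group of 7 heavy atoms (7 carbon; one six-membered aromatic ring of carbon only), on a carbonyl carbon. Going by the values given here, no measured step touches that carbonyl carbon, so no step beyond the scatter is expected in either direction, and compound 4 is estimated at 25 nM (range 8 nM to 80 nM), which means an expected step of a 1.1-fold higher number from compound 3 to compound 4 (0.06 log units; within the scatter).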

Compound 4, half-maximal inhibitory concentration: 43 nM
The estimate for compound 4 lay 1.7-fold (0.24 log units) below the measured number; the measured number falls inside the stated range.
By their numbers in this assay, from the lowest: compounds 3, 4 and 2 (each within the scatter of the next, the first and the last beyond it). At a limit, above all of these: compound 1.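

At the carbonyl carbon, the 4-methylphenyl group gives way to a group of 11 heavy atoms, including three fluorines, with a 2.0-fold higher number from compound 3 to compound 4 (0.29 log units; within the scatter). For the compounds shown here, this is the only measured step at this place, and it shows that the larger group can enter here without a change beyond the scatter. Nothing measured here accounts for this step.

On these data alone, whether a carboxylic acid or a primary amine on that aromatic ring would be accepted at this carbonyl carbon remains open. As far as these compounds go, compound 2 and compound 3 differ in more than one place, so their separate contributions also remain open.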